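Exchange of the five-membered heterocycle on the shared core

The compounds below may be only part of what the source reports. "The series", "measured", "known", "first", "only" and "open" are said of these compounds alone.

Measured compounds:
compound 1 `CC(C)C(/C=C1\NC(=O)NC1=O)c1ccc(-c2ccc3cccc(F)c3c2)[nH]c1=O` gives 87 nM
compound 2 `CC(C)C(c1ccc(-c2ccc3cccc(F)c3c2)[nH]c1=O)C1NC(=O)NC1=O` gives 320 nM
compound 3 `C/C(=C1/OC(=O)NC1=O)C(c1ccc(-c2ccc3cccc(F)c3c2)[nH]c1=O)C(C)C` gives 39 nM

All three were tested in a functional assay on CHO cells for antagonist activity at prostaglandin E2 receptor EP3 subtype (Homo sapiens), read by cAMP accumulation, with a stated time of 30 min; on this read-out lower numbers stand for stronger inhibition and higher numbers for weaker inhibition. Compound 3 stands lowest of the three numbers; the step of a 2.2-fold lower number from compound 1 to compound 3 (0.35 log units; beyond the scatter) and the step of an 8.2-fold lower number from compound 2 to compound 3 (0.91 log units; beyond the scatter) both lie beyond the scatter, so compound 3 is the most potent of the measured set, with compound 1 nearest to it and compound 2 furthest.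

Compound 4 `CC(C)C(/C=C1\SC(=O)NC1=O)c1ccc(-c2ccc3cccc(F)c3c2)[nH]c1=O` has not yet been measured. Against compound 3 the change is a group of 8 heavy atoms (4 carbon, 1 nitrogen, 2 oxygen, 1 sulfur; one five-membered non-aromatic ring with 2 hetero atoms) in place of a group of 9 heavy atoms (5 carbon, 1 nitrogen, 3 oxygen; one five-membered non-aromatic ring with 2 hetero atoms), on a saturated chain carbon bound to an aromatic carbon and a saturated chain carbon. Among the measured compounds shown here, no measured step exchanges an oxygen for a sulfur in the five-membered ring; the steps that bear on this position are a 2.2-fold lower number from compound 1 to compound 3 (0.35 log units; beyond the scatter) and an 8.2-fold lower number from compound 2 to compound 3 (0.91 log units; beyond the scatter), which show that replacing the heterocycle moves the number by a modest amount in either direction. Compound 4 also carries the same double bond outside the ring as compound 1, which gives 87 nM. The expectation is therefore a step of modest size or none beyond the scatter, a 1.4-fold higher number from compound 3 to compound 4 (0.15 log units; within the scatter), most likely a somewhat higher number. Compound 4 is estimated at 55 nM, with a range from 20 nM to 160 nM.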

Compound 4, half-maximal inhibitory concentration: 27 nM
Estimate against measurement, compound 4: 2.0-fold (0.31 log units) above, and the stated range covers the measured number.
By their numbers in this assay, from the lowest: compounds 4 and 3 (each within the scatter of the next); then compound 1; then compound 2.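

Notes on the sulfur-containing ring: in this assay, exchanging a ring nitrogen of the group in compound 1 for sulfur gives a 3.2-fold lower number from compound 1 to compound 4 (0.51 log units; beyond the scatter), so a change of one ring atom is enough to move the number beyond the scatter at this position. Against the group with a ring oxygen and one further carbon, the result is a 1.4-fold lower number from compound 3 to compound 4 (0.16 log units; within the scatter), so the sulfur and oxygen groups cannot be ordered, and two of the ring groups now sit together in the low part of the series. Among the compounds shown here, the widest gap in the set is a 12-fold lower number from compound 2 to compound 4 (1.07 log units; beyond the scatter), the first step here graded large, and it separates the group carrying sulfur and the double bond outside the ring from the saturated group with two ring nitrogens. Nothing available explains any of these steps.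

Still open, going by these compounds, is whether the saturated form of the sulfur-containing ring would stay with compound 4 or fall towards compound 2. Also open, on these data alone, is how a carboxylic acid or a tetrazole would compare with these ring groups on a saturated chain carbon bound to an aromatic carbon and a saturated chain carbon.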